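Phenoxy to isoquinolinyloxy on the anilide series: distribution expectation

The source may report more compounds than this note shows. Statements on the series, on what has been measured and on what is new or still open speak of the compounds shown alone.

Measured so far:
compound 1 `Cc1cn(-c2cc(NC(=O)c3ccc(C)c(Oc4ccccc4)c3)cc(C(F)(F)F)c2)cn1`, 1.69 L/kg
compound 2 `Cc1cn(-c2cc(NC(=O)c3ccc(C)c(Oc4ccccc4)c3)cc(N3CCN(C)CC3)c2)cn1`, 9.26 L/kg

In an ADME assay on the whole organism (Mus musculus, strain CD1) for pharmacokinetics, read by LC-MS, using cassette dosing, with a stated time of 24 h, at a dose of 0.4 mg/kg by the intravenous route (on this read-out higher numbers stand for wider distribution into tissues and lower numbers for narrower distribution), compound 1 gives 1.69 L/kg, and compound 2 gives 9.26 L/kg; the step is a 5.5-fold higher number from compound 1 to compound 2 (0.74 log units; beyond the scatter). Compound 2 therefore holds the higher of the two numbers in this assay.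

Compound 3 `Cc1cn(-c2cc(NC(=O)c3ccc(C)c(Oc4cccc5ccncc45)c3)cc(N3CCN(C)CC3)c2)cn1` differs from compound 2 by isoquinolin-8-yl in place of phenyl on an oxygen on an aromatic ring. Among the measured compounds shown here, no measured step touches this part of the molecule; the one step from compound 1 to compound 2 changes another position and gives no guide here. A step of modest size at most, or none beyond the scatter, is expected in this assay. Compound 3 is estimated at 9 L/kg, within 4 L/kg to 20 L/kg, which is an expected step of a 1.0-fold lower number from compound 2 to compound 3 (0.01 log units; within the scatter).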

Compound 3, volume of distribution at steady state: 6.7 L/kg
Beside the measured number, compound 3's estimate is 1.3-fold (0.13 log units) above it; the measured number falls inside the stated range.
By their numbers in this assay, from the lowest: compound 1; then compounds 3 and 2 (each within the scatter of the next).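

In this assay, isoquinolin-8-yl in place of phenyl on the oxygen gives a 1.4-fold lower number from compound 2 to compound 3 (0.14 log units; within the scatter), so on the 4-methylpiperazin-1-yl background this position takes the second ring and its hydrogen-bond acceptor without a step beyond the scatter. Among the compounds shown here, this is the first reading at this position, and it sets the phenoxy and (isoquinolin-8-yl)oxy forms level on this read-out. No measurement at hand bears on the reason. Open, from the compounds shown here alone, is whether the same exchange reads alike with trifluoromethyl in place of 4-methylpiperazin-1-yl, and whether a pyridinyl group on that oxygen also stays within the scatter.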